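Cyano for trifluoromethoxy on two related cores

A few compounds are considered here, and "the series" means these few. Any claim that something is new, unique, unknown or untested is made for them only; others in the source may bear on it.

Compound 1 `CC(O)(COc1ccc(OC(F)(F)F)cc1)C(=O)Nc1ccc(S(F)(F)(F)(F)F)cc1` and compound 2 `CC(O)(COc1ccc(C#N)cc1)C(=O)Nc1ccc(S(F)(F)(F)(F)F)cc1` share one core. In a functional assay on CWR22R cells (Homo sapiens) for antiproliferative activity, read by propidium iodide staining, with a stated time of 96 h (on this read-out lower numbers stand for stronger inhibition and higher numbers for weaker inhibition), compound 1 gives 27900 nM, and compound 2 gives 26100 nM. The change between them, (cyano in place of trifluoromethoxy on an aromatic carbon), produced a 1.1-fold lower number from compound 1 to compound 2 (0.03 log units; within the scatter). Compound 3 `CC(O)(COc1ccc(OC(F)(F)F)cc1)C(=O)Nc1cccc(S(F)(F)(F)(F)F)c1` carries a different core; the difference between the two cores is not broken down here. In this assay compound 3 gives 12900 nM, the lowest of the three numbers. Compound 4 `CC(O)(COc1ccc(C#N)cc1)C(=O)Nc1cccc(S(F)(F)(F)(F)F)c1` differs from compound 3 by cyano in place of trifluoromethoxy on an aromatic carbon, the same change as that from compound 1 to compound 2. The step of a 1.0-fold lower number from compound 3 to compound 4 (0.01 log units; within the scatter) is expected to be small, because a 1.1-fold lower number from compound 1 to compound 2 (0.03 log units; within the scatter) lay within the scatter. Compound 4 is therefore estimated at 12500 nM in this assay, expected to lie between 6000 nM and 26000 nM.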

Compound 4, half-maximal inhibitory concentration: 32500 nM
For compound 4 the middle estimate is 2.6-fold (0.41 log units) below the measured one, and the stated range ends below it.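

In this assay, the change of trifluoromethoxy to cyano gives a 2.5-fold higher number from compound 3 to compound 4 (0.40 log units; beyond the scatter), so a result on one core did not predict the result on the other. For the compounds shown here, this shows only that the step need not carry over between these two cores; with two pairs it gives no rule for other cores and does not explain the gap. The two steps differ clearly: the same change on two cores in this assay, a 1.1-fold lower number (0.03 log units; within the scatter) from compound 1 to compound 2 and a 2.5-fold higher number (0.40 log units; beyond the scatter) from compound 3 to compound 4, 2.7-fold (0.43 log units) apart, beyond the scatter of two such steps

The compounds shown leave open whether an amine or a carboxylic acid at the same place on the aromatic ring would also give different steps on the two cores. They also leave open which of the two steps, if either, a third core would follow.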